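Changing the sulfonyl substituent on a shared core: compound 3

The source may report more compounds than this note shows. Statements on the series, on what has been measured and on what is new or still open speak of the compounds shown alone.

Compound 1, `COC(=O)CC(=O)N1N=C(c2ccc(N3CCN(C)CC3)cc2)CC1c1ccc(N(C)C)cc1`, gives -8.3% in a functional assay on HCC1806 cells (Homo sapiens) for inhibition, read by sulforhodamine B assay, tested at 10 uM; a lower number here means less inhibition, a higher number more inhibition at the concentration tested (going by the name of the read-out).
Compound 2, `CN1CCN(c2ccc(C3=NN(S(=O)(=O)C4CC4)C(c4ccc(N(C)C)cc4)C3)cc2)CC1`, gives 4.7% in this assay.

Within the data shown here, compound 2 stands highest of the two numbers measured so far, and the only measured step, a number 13 percentage points higher from compound 1 to compound 2 (beyond the scatter), leads to it. That step exchanged the whole group on the ring nitrogen of the core, a cyclopropylsulfonyl in place of ((methoxycarbonyl)methyl)carbonyl, and shifted the read-out modestly.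

Compound 3, `CN1CCN(c2ccc(C3=NN(S(=O)(=O)c4ccc(C(F)(F)F)cc4)C(c4ccc(N(C)C)cc4)C3)cc2)CC1`, keeps the sulfonyl group of compound 2 but changes what sits on it: 4-(trifluoromethyl)phenyl in place of cyclopropyl on a sulfonyl sulfur. Among the measured compounds shown here, no measured step alters the group on the sulfonyl sulfur, so the step from compound 1 to compound 2 bears on compound 3 only in showing that changes at this part of the core have moved the read-out by a modest amount. Both measured values lie near zero inhibition. Compound 3 is therefore expected to stay in the same low region, with an estimated step of a number 3.3 percentage points higher from compound 2 to compound 3 (within the scatter). Compound 3 is estimated at 8%, within a range from -12% to 30%.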

Compound 3, a percentage reported as inhibition, at one concentration (the size of the read-out at that concentration, not a potency): 27%
Compound 3: middle estimate off by 19 percentage points, on the low side; the measured number falls inside the stated range.
By their numbers in this assay, from the lowest: compound 1; then compound 2; then compound 3.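

The group carried on the sulfonyl sulfur matters in this assay: with the sulfonamide nitrogen in a ring and the rest of the shared core left as they were, 4-(trifluoromethyl)phenyl in place of cyclopropyl gives a number 22.3 percentage points higher from compound 2 to compound 3 (beyond the scatter), a modest change that still lies beyond the scatter. The earlier step exchanged the whole group on the ring nitrogen, so it could not show whether the sulfonyl substituent alone moves the number, and this step shows that it does. Nothing measured here speaks to why the number rises with this exchange.

The change brings in a six-membered aromatic ring and a trifluoromethyl group together, so these compounds leave open whether the ring alone accounts for the step or whether the trifluoromethyl group contributes, a question that a plain phenyl on the sulfur, or a phenyl carrying a methoxy group or a chlorine atom in its place, would help to separate. They also leave open whether a longer alkyl chain on the sulfur would move the number in the same way, and how the compounds would rank across a range of concentrations rather than at the single one tested.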